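Swapping the Cyclohexyl Amide for a Thiazolyl Amide

A few compounds are considered here, and "the series" means these few. Any claim that something is new, unique, unknown or untested is made for them only; others in the source may bear on it.

Compound 1, `O=C(Nc1ccc(Cl)cc1CN1C(=O)c2ccccc2C1=O)c1cccnc1`, gives 35000 nM in an assay on CHO cells for positive allosteric modulation of metabotropic glutamate receptor 5 (Homo sapiens), read by FLIPR; on this read-out higher numbers stand for an effect only at larger amounts of compound and lower numbers for an effect already at smaller amounts.
Compound 2, `O=C(Nc1ccc(Cl)cc1CN1C(=O)c2ccccc2C1=O)c1ncccn1`, gives 2100 nM in this assay.
Compound 3, `O=C(Nc1ccc(Cl)cc1CN1C(=O)c2ccccc2C1=O)C1CCCCC1`, gives 1500 nM in this assay.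

Compound 3 has the lowest of the three numbers, but its gap to compound 2 is within the scatter, so the two cannot be ordered; only compound 1 stands clearly apart, as a 23-fold lower number from compound 1 to compound 3 (1.37 log units; beyond the scatter) shows. The unmeasured compound 4, `O=C(Nc1ccc(Cl)cc1CN1C(=O)c2ccccc2C1=O)c1cncs1`, differs from compound 3 by 1,3-thiazol-5-yl in place of cyclohexyl on a carbonyl carbon.

Going by the values given here, two measured steps bear on this change. The step of a 1.4-fold lower number from compound 2 to compound 3 (0.15 log units; within the scatter) shows that one aromatic ring on the carbonyl can sit on a par with cyclohexyl, whereas a 17-fold lower number from compound 1 to compound 2 (1.22 log units; beyond the scatter) shows that two aromatic rings on the same carbon can differ widely. Among the compounds with values here, no measured step contains 1,3-thiazol-5-yl itself, so its place between these outcomes is unknown. Because of a 1.4-fold lower number from compound 2 to compound 3 (0.15 log units; within the scatter) a small upward step is the most likely reading, with room for a larger one in view of a 23-fold lower number from compound 1 to compound 3 (1.37 log units; beyond the scatter).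

For compound 4 a number of 4000 nM is therefore expected in this assay, within 1200 nM to 20000 nM. This estimate corresponds to a 2.7-fold higher number from compound 3 to compound 4 (0.43 log units; beyond the scatter).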

Compound 4, half-maximal effective concentration: 1900 nM
Compound 4: middle estimate off by 2.1-fold (0.32 log units), on the high side; measured number inside the range.
By their numbers in this assay, from the lowest: compounds 3, 4 and 2 (each within the scatter of the next); then compound 1.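

In this assay, the place on a carbonyl carbon whose other neighbour is the amide-type nitrogen takes a five-membered aromatic ring with 2 hetero atoms as well as it takes cyclohexyl (a 1.3-fold higher number from compound 3 to compound 4 (0.10 log units; within the scatter)), although 1,3-thiazol-5-yl brings 2 hydrogen-bond acceptors and cyclohexyl brings none. The same group cannot be told apart from pyrimidin-2-yl (a 1.1-fold lower number from compound 2 to compound 4 (0.04 log units; within the scatter)) but stands clearly apart from pyridin-3-yl (an 18-fold lower number from compound 1 to compound 4 (1.27 log units; beyond the scatter)), so two aromatic rings and cyclohexyl now share one band of numbers, and compound 1, with its aromatic ring, is the only one of the four outside it. No measurement among those shown accounts for the separate place of compound 1.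

The compounds shown leave open how pyridin-2-yl or 1,3-thiazol-2-yl would compare, and so whether the gap belongs to pyridin-3-yl alone or extends to other rings. They also leave open whether a carboxylic acid, an amine or an open chain such as tert-butyl on the same carbonyl carbon would stay with compound 3 and compound 4 or fall away as compound 1 does.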